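The source may report more compounds than this note shows. Statements on the series, on what has been measured and on what is new or still open speak of the compounds shown alone.

Of the compounds shown here, three with a shared core have been tested in a functional assay on cells (Cancer cell lines, Homo sapiens) for cytotoxicity, read by sulforhodamine B assay, with a stated time of 48 h; on this read-out higher numbers stand for weaker inhibition of growth and lower numbers for stronger inhibition of growth. Compound 1 `COc1ccc(C2CC(c3ccc4ccccc4c3)=NN2C2=NC(=O)/C(=C3\C(=O)Nc4ccccc43)S2)cc1` gives 620 nM in this assay. Compound 2 `COc1ccc(C2CC(c3ccc4ccccc4c3)=NN2C2=NC(=O)/C(=C3\C(=O)Nc4ccc(Br)cc43)S2)cc1` carries one change, (bromo in place of hydrogen on an aromatic carbon), and in this assay compound 2 gives 54 nM; the step is an 11-fold lower number from compound 1 to compound 2 (1.06 log units; beyond the scatter). Compound 3 `CN(C)c1ccc(C2CC(c3ccccc3)=NN2C2=NC(=O)/C(=C3\C(=O)Nc4ccccc43)S2)cc1` has a different core; how the core of compound 3 differs from the core of compound 1 is not broken down here. In this assay compound 3 gives 7420 nM, the highest of the three numbers.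

Compound 4 `CN(C)c1ccc(C2CC(c3ccccc3)=NN2C2=NC(=O)/C(=C3\C(=O)Nc4ccc(Br)cc43)S2)cc1` has not yet been measured. It differs from compound 3 by bromo in place of hydrogen on an aromatic carbon, the same kind of change that turned compound 1 into compound 2, made at a place described in the same words. Because the earlier step was an 11-fold lower number from compound 1 to compound 2 (1.06 log units; beyond the scatter), a step of similar size is expected here, though it rests on a single precedent on a different core. The step from compound 3 to compound 4 is estimated as a 9.3-fold lower number from compound 3 to compound 4 (0.97 log units; beyond the scatter). For compound 4 the expected value is 800 nM, between 300 nM and 2500 nM.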

Compound 4, concentration for 50% growth inhibition: 220 nM
The estimate for compound 4 lay 3.6-fold (0.56 log units) above the measured number; measured number below the stated range.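

The step of a 34-fold lower number from compound 3 to compound 4 (1.53 log units; beyond the scatter) in this assay points the same way as the step on the core of compound 1, so bromo in place of hydrogen on an aromatic carbon lowered the number on both cores. The size of the step did not carry over unchanged, and the gap between the two steps is larger than repeated measurements would be expected to produce: the same change on two cores in this assay, an 11-fold lower number (1.06 log units; beyond the scatter) from compound 1 to compound 2 and a 34-fold lower number (1.53 log units; beyond the scatter) from compound 3 to compound 4, 2.9-fold (0.47 log units) apart, beyond the scatter of two such steps. Among the compounds shown here, with only two pairs, this does not show how large the step would be on a third core, nor which difference between the two cores goes with the larger step.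

The compounds shown leave open whether a different group at this place, such as chloro, an amine or a carboxylic acid, would lower the number as bromo does. They also leave open what bromo would do on another aromatic carbon of the same ring.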